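From a Limit Towards a Measurable Value

The source may hold more compounds than are shown below. What is called first, only, known or untested is meant among the compounds shown, and "the series" means these compounds.

In a functional assay on HeLa cells (Homo sapiens) for antiproliferative activity, read by MTT assay, with a stated time of 72 h (a higher number here means a weaker inhibitor, a lower number a stronger inhibitor), compound 2 `Cc1noc(C)c1-c1nn(Cc2ccc(C(=O)NC3CCN(C)CC3)cc2)c(=O)c2ccccc12` gives > 100000 nM, which is a limit of the assay and not a number. Compound 3 `Cc1noc(C)c1-c1nn(Cc2ccc(C(=O)NC3CCCC3)cc2)c(=O)c2ccccc12` carries cyclopentyl in place of 1-methylpiperidin-4-yl on an amide-type nitrogen. Compound 1 `Cn1cc(-c2nn(Cc3ccc(C(=O)NC4CCCC4)cc3)c(=O)c3ccccc23)cn1`, which also carries cyclopentyl on an amide-type nitrogen, gives 16700 nM in this assay, and on that value compound 3 is expected to be a clearly stronger inhibitor than compound 2. The expected size of this change is an estimated at least 5.0-fold lower number from compound 2 to compound 3 (0.69 log units; beyond the scatter). Compound 3 is estimated at 20000 nM, with an expected range of 6000 nM to 70000 nM.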

Compound 3, half-maximal inhibitory concentration: > 100000 nM
Compound 3 was reported as a limit; the forecaster's own chance of this, stated with the estimate: 15%; middle value at least 5.0-fold (0.69 log units) away from the limit.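

In this assay compound 3 gives > 100000 nM, which is a limit of the assay and not a number. With cyclopentyl held on the amide-type nitrogen, 3,5-dimethyl-1,2-oxazol-4-yl in place of 1-methyl-1H-pyrazol-4-yl on the aromatic carbon weakens the compound, with an at least 5.9-fold higher number from compound 1 to compound 3 (0.77 log units; beyond the scatter). The exchange of 1-methylpiperidin-4-yl for cyclopentyl cannot be read, because both of its compounds sit at one limit: the limit of > 100000 nM in this assay, at which 2 of the 3 values shown sit.

Still open, going by these compounds, is whether 3,5-dimethyl-1,2-oxazol-4-yl compounds reach a measurable value with another group on that nitrogen, such as a carboxylic acid or a primary amine on a longer chain. Also open, on these data alone, is how 1-methylpiperidin-4-yl reads alongside 1-methyl-1H-pyrazol-4-yl.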